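A few compounds are considered here, and "the series" means these few. Any claim that something is new, unique, unknown or untested is made for them only; others in the source may bear on it.

For the measured compounds named here, compound 1 `NC(=O)c1ccc(-c2cnc3ccc(-c4cccc(S(=O)(=O)C5CC5)c4)nn23)cc1` is the only member of this set with a number in a physicochemical assay for solubility, at pH 2 (on this read-out lower numbers stand for lower solubility and higher numbers for higher solubility), where compound 1 gives 6300 nM. Compound 2 `CS(=O)(=O)c1ccc(-c2cnc3ccc(-c4cccc(S(=O)(=O)C5CC5)c4)nn23)cn1` carries a 6-(methylsulfonyl)pyridin-3-yl group in place of the 4-carbamoylphenyl group of compound 1. In this assay compound 2 returns only a limit, < 5000 nM. From the compounds shown here alone, the step of an at least 1.2-fold lower number from compound 1 to compound 2 (0.10 log units; that floor lies within the scatter) has a floor that lies within the scatter, so its true size remains open; the limit of < 5000 nM in this assay, at which 1 of the 2 values shown sits, records that limit. Compound 3 `O=S(=O)(c1cccc(-c2ccc3ncc(-c4ccc(-c5nnn[nH]5)cc4)n3n2)c1)C1CC1` differs from compound 1 by 1H-tetrazol-5-yl in place of carbamoyl on an aromatic carbon. Going by the values given here, no measured step exchanges the carbamoyl group on its own, so the single step available serves only as a loose guide. The estimated step of a 2.1-fold lower number from compound 1 to compound 3 (0.32 log units; beyond the scatter) points somewhat downward. The estimated value for compound 3 in this assay is 3000 nM, within a range from 800 nM to 12000 nM.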

Compound 3, solubility: < 5000 nM
Compound 3: only a limit was reported; the forecaster's own chance of this, stated with the estimate: 50%; the middle value does not contradict the limit.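

For the compounds shown here, compound 3 is the first case in which the carbamoyl group alone is exchanged, on an aromatic carbon para to a large group, while the six-membered aromatic ring of carbon only stays in place. In this assay, from the compounds shown here alone, compound 3 gives a limit and not a number, so this change is read only as an at least 1.2-fold lower number from compound 1 to compound 3 (0.10 log units; that floor lies within the scatter), and its true size remains open. Compound 2 and compound 3 therefore cannot be ordered against each other, and limits now make up most of the values in this set: the limit of < 5000 nM in this assay, at which 2 of the 3 values shown sit.

The compounds shown leave open how far compound 3 truly lies from compound 1. They also leave open whether a carboxylic acid or an amine on the same carbon would return a number in this assay.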